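Compound 3 to compound 4: removing chloro

A few compounds are considered here, and "the series" means these few. Any claim that something is new, unique, unknown or untested is made for them only; others in the source may bear on it.

Of the compounds shown here, three on the shared core have been measured. Going by the values given here, in a functional assay for inhibition, with Homo sapiens as the target (a lower number here means a stronger inhibitor, a higher number a weaker inhibitor), compound 1 (`COc1ccc2c(OC(C)C)c(C(=O)Nc3nn[nH]n3)sc2c1`) gives 37000 nM, the only true number so far. In this assay compound 2 (`COc1cccc2c(OC(C)C)c(C(=O)Nc3nn[nH]n3)sc12`) gives > 100000 nM, which is a limit of the assay. In this assay compound 3 (`CC(C)Oc1c(C(=O)Nc2nn[nH]n2)sc2ccc(Cl)cc12`) gives > 100000 nM, which is also a limit and not a number. Compound 3 therefore stands at the limit of > 100000 nM in this assay, at which 2 of the 3 values shown sit.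

Compound 4 (`CC(C)Oc1c(C(=O)Nc2nn[nH]n2)sc2ccccc12`) has not been measured. It carries hydrogen in place of chloro on an aromatic carbon of compound 3: hydrogen in place of chloro on an aromatic carbon. Among the compounds with values here, no measured pair differs in one place only, so the expectation rests on indirect ground: compound 1 at 37000 nM shows that a number can be read on this shared core. A modest move towards stronger inhibition in this assay is expected, estimated as an at least 1.6-fold lower number from compound 3 to compound 4 (0.22 log units; that floor lies within the scatter), and it may not clear the scatter. Compound 4 is expected at 60000 nM, with an estimated range from 20000 nM to 200000 nM.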

Compound 4, half-maximal inhibitory concentration: > 100000 nM
Compound 4: a limit, no number; the forecaster's own chance of this, stated with the estimate: 45%; at least 1.6-fold (0.22 log units) between middle value and limit.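

In this assay compound 4 gives > 100000 nM as a limit of the assay and not a number. Hydrogen in place of chloro on this aromatic carbon therefore yields no readable number, and the steps from compound 3 and from compound 2 to compound 4 cannot be read, as both ends are limits. The one readable change is hydrogen in place of methoxy, with an at least 2.7-fold higher number from compound 1 to compound 4 (0.43 log units; beyond the scatter) and so beyond the scatter, although compound 2 also carries a methoxy group and goes against any pattern for methoxy as such; most of the series now sits at one level: the limit of > 100000 nM in this assay, at which 3 of the 4 values shown sit.

How chloro and hydrogen compare on this carbon remains unresolved beyond the limit. Also open, as far as these compounds go, is whether an amine or a carboxylic acid at this place would give a number on the shared core.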